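The source may report more compounds than this note shows. Statements on the series, on what has been measured and on what is new or still open speak of the compounds shown alone.

Compound 1 `COc1ccc(-c2cn3ccnc3c(-c3ccc4ncn(C5CCCCC5)c4c3)n2)cc1` carries a 4-methoxyphenyl on the shared core, and in a physicochemical assay for lipophilicity, using the shake flask method, in phosphate buffer, measured as octanol-water partition, with a stated time of 85 min, at pH 7.4 (a higher number here means a more lipophilic compound, a lower number a more polar compound), compound 1 gives 1.41. Compound 2 `Fc1ccc(-c2cn3ccnc3c(-c3ccc4ncn(C5CCCCC5)c4c3)n2)cc1` differs from it by fluoro in place of methoxy on an aromatic carbon and in this assay compound 2 gives 2.01, which amounts to a number 0.60 log units higher from compound 1 to compound 2 (beyond the scatter). Compound 3 `COc1ccccc1-c1cn2ccnc2c(-c2ccc3ncn(C4CCCCC4)c3c2)n1` has the same atoms as compound 1 joined differently, the difference being (2-methoxyphenyl in place of 4-methoxyphenyl on an aromatic carbon); in this assay compound 3 gives 1.72. Against compound 1 this is a number 0.31 log units higher from compound 1 to compound 3 (beyond the scatter), while against compound 2 it is a number 0.29 log units lower from compound 2 to compound 3 (within the scatter). Compound 4 `Fc1ccccc1-c1cn2ccnc2c(-c2ccc3ncn(C4CCCCC4)c3c2)n1` has not been measured yet; it differs from compound 3 by fluoro in place of methoxy on an aromatic carbon. Among the compounds with values here, this is the same kind of change as the one between compound 1 and compound 2, though not the same: there the fluoro sits para to a large group, here ortho to a large group. In this assay the expected step is a number 0.48 log units higher from compound 3 to compound 4 (beyond the scatter), which rests on a number 0.60 log units higher from compound 1 to compound 2 (beyond the scatter), tempered slightly for the different place. Compound 4 is thus estimated at 2.2 in this assay, between 1.9 and 2.6.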

Compound 4, partition coefficient: 1.95
For compound 4 the middle estimate is 0.25 log units above the measured one; low and high end bracket the measured number.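

Moved to the core of compound 3, where the group sits ortho to a large group, fluoro in place of methoxy gives a step in this assay (a number 0.23 log units higher from compound 3 to compound 4 (within the scatter)) that points the same way as the one seen for the para pair (a number 0.60 log units higher from compound 1 to compound 2 (beyond the scatter)), but only that earlier step lies beyond the scatter, so compound 3 and compound 4 cannot be told apart here. The two fluoro compounds also cannot be separated (a number 0.06 log units lower from compound 2 to compound 4 (within the scatter)), while the step between the methoxy and fluoro compounds that differ in both group and place is clear (a number 0.54 log units higher from compound 1 to compound 4 (beyond the scatter)). One pair on each core shows that the direction carried over once, not that the size of the step carries over, and nothing available explains the result.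

The compounds shown leave open whether the step would hold for a chloro, an amine or a carboxylic acid in the same place. They also leave open whether it would hold with a longer chain elsewhere on the shared core.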